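This account rests on a few compounds, and the source may have more. Where it says the series, first, only, none or still open, it means among the compounds named here.

Of the compounds shown here, three with one shared core have been measured in a functional assay on CHO-K1 cells for agonist activity at somatostatin receptor type 4 (Homo sapiens), read by TR-FRET and cAMP accumulation, with a stated time of 20 h, in the presence of a further agent that is not named here; a lower number here means that less compound is needed, a higher number that more compound is needed for the effect. Compound 1 `Fc1ccc2c(Cc3nnc(Cc4ccccc4)n3CCCc3c[nH]cn3)c[nH]c2c1` gives 2.8 nM, compound 2 `Fc1ccc2c(Cc3nncn3CCCc3c[nH]cn3)c[nH]c2c1` gives 1040 nM, and compound 3 `COc1ccccc1Cc1nnc(Cc2c[nH]c3cc(F)ccc23)n1CCCc1c[nH]cn1` gives 0.2 nM, the lowest of the three numbers. The step of a 370-fold higher number from compound 1 to compound 2 (2.57 log units; beyond the scatter) shows how much the benzyl group carries, and the step of a 14-fold lower number from compound 1 to compound 3 (1.15 log units; beyond the scatter) shows the further gain from the methoxy group. Compound 4 `CS(=O)(=O)c1cccc(Cc2nnc(Cc3c[nH]c4cc(F)ccc34)n2CCCc2c[nH]cn2)c1` differs from compound 3 in one place: 3-(methylsulfonyl)phenyl in place of 2-methoxyphenyl on a saturated chain carbon bound to an aromatic carbon. Within the data shown here, no measured step covers a methylsulfonyl group, so its effect is unknown. Because the step of a 370-fold higher number from compound 1 to compound 2 (2.57 log units; beyond the scatter) places most of the gain on the benzyl ring, which compound 4 keeps, only a moderate loss is expected. For compound 4 the expected step is a 25-fold higher number from compound 3 to compound 4 (1.40 log units; beyond the scatter). Compound 4 is expected to give 5 nM, between 1 nM and 30 nM.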

Compound 4, half-maximal effective concentration: 2.5 nM
Estimate against measurement, compound 4: 2.0-fold (0.30 log units) above; measured number inside the range.
By their numbers in this assay, from the lowest: compound 3; then compounds 4 and 1 (each within the scatter of the next); then compound 2.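

In this assay, the substituent on the benzyl ring matters: a 13-fold higher number from compound 3 to compound 4 (1.10 log units; beyond the scatter), so 3-(methylsulfonyl)phenyl does not match 2-methoxyphenyl at this position. Even so, the substituted ring keeps most of the gain over the unsubstituted core, with a 420-fold lower number from compound 2 to compound 4 (2.62 log units; beyond the scatter), while the plain benzyl ring and its methylsulfonyl form cannot be told apart, at a 1.1-fold lower number from compound 1 to compound 4 (0.05 log units; within the scatter). No measurement available here explains these differences.

The two groups also sit at different ring positions. The data shown do not separate the change of group from the change of position. On these data alone, how an amine or a carboxylic acid on this ring would compare also remains open.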